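From pyridin-3-yl to 1-methyl-1H-pyrazol-5-yl on the carbonyl

This account rests on a few compounds, and the source may have more. Where it says the series, first, only, none or still open, it means among the compounds named here.

Three measured compounds share one core and differ only in the group on the carbonyl carbon. Compound 1 `O=C(NCc1ccc(CNS(=O)(=O)c2ccc3c(c2)CCO3)cc1)c1scc2c1OCCO2` gives 0% in a functional assay on the whole organism for inhibition, with Mus musculus as the target, with stated times of 30 min and 2 h, at a dose of 10 mg/kg by the intraperitoneal route; a higher number here means more inhibition at the dose given (going by the name of the read-out), a lower number less inhibition. Compound 2 `Cc1cc(C(=O)NCc2ccc(CNS(=O)(=O)c3ccc4c(c3)CCO4)cc2)n(C)n1` gives 35% in this assay, and compound 3 `O=C(NCc1ccc(CNS(=O)(=O)c2ccc3c(c2)CCO3)cc1)c1cccnc1` gives 10% there. Compound 3 stands second highest of the three numbers: its value and that of compound 1 lie within the scatter of each other, whereas the step of a number 25 percentage points lower from compound 2 to compound 3 (beyond the scatter) lies beyond it. Compound 4 `Cn1nccc1C(=O)NCc1ccc(CNS(=O)(=O)c2ccc3c(c2)CCO3)cc1` has not yet been measured; it differs from compound 3 by 1-methyl-1H-pyrazol-5-yl in place of pyridin-3-yl on a carbonyl carbon. The measured step of a number 25 percentage points lower from compound 2 to compound 3 (beyond the scatter) bears on this change, as compound 2 carries the 1,3-dimethyl-1H-pyrazol-5-yl group, which is the entering group of compound 4 with one more methyl. Reversing much of that step, a rise beyond the scatter is expected for compound 4, namely a number 15 percentage points higher from compound 3 to compound 4 (beyond the scatter). For compound 4 the estimated value in this assay is 25%, within a range of 5% to 45%.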

Compound 4, a percentage reported as inhibition, in the whole organism at one dose (the size of the read-out at that dose, not a potency): 38%
Compound 4: middle estimate off by 13 percentage points, on the low side, within the range that was stated.
By their numbers in this assay, from the lowest: compounds 1 and 3 (each within the scatter of the next); then compounds 2 and 4 (each within the scatter of the next).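

In this assay, hydrogen in place of methyl on an aromatic carbon gives a number 3 percentage points higher from compound 2 to compound 4 (within the scatter), so the extra methyl of the 1,3-dimethyl-1H-pyrazol-5-yl group does not set compound 2 and compound 4 apart. The change of 1-methyl-1H-pyrazol-5-yl in place of pyridin-3-yl on the carbonyl carbon can now be read directly as a number 28 percentage points higher from compound 3 to compound 4 (beyond the scatter), and the same group set against the larger group of compound 1 gives a number 38 percentage points higher from compound 1 to compound 4 (beyond the scatter). Nothing measured here accounts for these steps.

Still open, going by these compounds, is how a 1-ethyl-1H-pyrazol-5-yl group, or a group carrying an amine or a carboxylic acid, would read on the carbonyl carbon. The read-out, taken at one dose, also gives no potency for any of the four compounds.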